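Methoxy for Methyl on a Shared Core: Cytotoxicity Outlook

This account rests on a few compounds, and the source may have more. Where it says the series, first, only, none or still open, it means among the compounds named here.

Compound 1, `Cc1ccc(S(=O)(=O)N2CCC3(CC2)OOC2(CCCC2)OO3)cc1`, in a functional assay on Huh-7 cells (Homo sapiens) for cytotoxicity, read by MTT assay, with a stated time of 72 h (on this read-out lower numbers stand for higher toxicity in this test and higher numbers for lower toxicity in this test), gives > 100 ug/mL, which is a limit of the assay and not a number.
Compound 2, `Cc1ccc(S(=O)(=O)N2CCC3(CC2)OOC2(CCCCC2)OO3)cc1`, in this assay gives > 100 ug/mL, again a limit.
Compound 3, `COc1ccc(S(=O)(=O)N2CCC3(CC2)OOC2(CCCC2)OO3)cc1`, in this assay gives > 100 ug/mL, also a limit.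

All three measured compounds therefore sit at one point, (the limit of > 100 ug/mL in this assay, at which 3 of the 3 values shown sit), and none of them yields a number that could be compared. The change from compound 1 to compound 3 is methoxy in place of methyl on an aromatic carbon. Because both ends of that change are limits, the step that the two limits leave unreadable from compound 1 to compound 3 cannot be read. Compound 2 differs from compound 1 in the core, and that difference is not broken down here.

Compound 4, `COc1ccc(S(=O)(=O)N2CCC3(CC2)OOC2(CCCCC2)OO3)cc1`, has not yet been measured in this assay. It differs from compound 2 by methoxy in place of methyl on an aromatic carbon, and since the place of the change is the same in both pairs, this is the same change that turns compound 1 into compound 3. The expected step that the limit leaves unreadable from compound 2 to compound 4 rests on the fact that compound 3 gives only the limit > 100 ug/mL after this change. Compound 2 itself gives only the limit > 100 ug/mL. On that basis compound 4 is expected to give about 150 ug/mL, with a range estimated from 70 ug/mL to 300 ug/mL, and most probably the assay will again report only a limit.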

Compound 4, half-maximal cytotoxic concentration: > 100 ug/mL
Compound 4 ended at the assay's limit; the forecaster's own chance of this, stated with the estimate: 85%; the middle value is on the limit's open side.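

Among the compounds shown here, compound 4, like compound 2, gives a limit and not a number, so the change from methyl to methoxy between these two compounds yields no new step that can be read. All the compounds shown now sit at one point: the limit of > 100 ug/mL in this assay, at which 4 of the 4 values shown sit. What they leave open is the actual value of each compound in this assay and whether methoxy in place of methyl changes it at all.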